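The source may hold more compounds than are shown below. What is called first, only, known or untested is meant among the compounds shown, and "the series" means these compounds.

Measured so far in a functional assay on NIH3T3 cells (Mus musculus); on this read-out lower numbers stand for an effect already at smaller amounts and higher numbers for an effect only at larger amounts of compound:

- compound 1 `COC(=O)[C@H](CCSC)NC(=O)c1ccc(CNCc2c[nH]cn2)cc1-c1ccccc1C` gives 25 uM
- compound 2 `CSCC[C@H](NC(=O)c1ccc(CNCc2c[nH]cn2)cc1-c1ccccc1C)C(=O)O` gives > 25 uM (a limit)
- compound 3 `CSCC[C@H](NC(=O)c1ccc(CNCc2[nH]cnc2C)cc1-c1ccccc1C)C(=O)O` gives > 10 uM (a limit)

Compound 2 has no exact number in this assay and stands only at its limit of > 25 uM. Compound 3 is also known only by a limit, and compound 1 alone has a true number.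

The next compound is compound 4 `CSCC[C@H](NC(=O)c1ccc(CNCc2c[nH]cn2)cc1-c1ccccc1C)C(=O)OC(C)C`, which differs from compound 2 by one change: isopropyl in place of hydrogen on an oxygen next to a carbonyl group. In words, this is isopropyl in place of hydrogen on an oxygen next to a carbonyl group, turning carboxy into isopropoxycarbonyl.

The closest measured change sits on that same oxygen but runs the other way, with hydrogen replacing methyl: a number no lower from compound 1 to compound 2 (the limit leaves the size open). Its size cannot be read. The other measured step, a step that the two limits leave unreadable from compound 2 to compound 3, concerns the imidazole end rather than this oxygen, so it offers no guide.

The best anchor is therefore compound 1, which carries methyl on that oxygen and gives 25 uM. On that basis, a modest move toward lower numbers is expected, with the estimated step being an at least 1.3-fold lower number from compound 2 to compound 4 (0.14 log units; that floor lies within the scatter). The estimate for compound 4 is 18 uM, with an expected range from 6 uM to 50 uM.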

Compound 4, concentration for half-maximal effect: 10 uM
Beside the measured number, compound 4's estimate is 1.8-fold (0.26 log units) above it, and the stated range covers the measured number.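

In this assay, among these compounds, isopropyl in place of hydrogen on this oxygen gives an at least 2.5-fold lower number from compound 2 to compound 4 (0.39 log units; beyond the scatter), the first step at this position whose size can be read at all, even if only as a floor. The true step could be larger, because compound 2 is known only by a limit: the limit of > 25 uM in this assay, at which 1 of the 4 values shown sits. Isopropyl in place of methyl on the same oxygen gives a 2.5-fold lower number from compound 1 to compound 4 (0.40 log units; beyond the scatter), so the two esters are not interchangeable here, and the group on this oxygen matters even when the carboxy group has already been capped as an ester.

Among the compounds shown here, the earlier steps from compound 1 to compound 2 and from compound 2 to compound 3 cannot be read, so it stays open how far the free carboxy compound really lies from either ester and whether the 4-methyl-1H-imidazol-5-yl end changes anything. Two esters do not make a series either: a tert-butyl or benzyl group on this oxygen, or an amide in place of the ester, could extend this step or reverse it.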